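The source may report more compounds than this note shows. Statements on the series, on what has been measured and on what is new or still open speak of the compounds shown alone.

Compound 2, `O=CCc1c(-c2ccccc2Cl)c2cc(Cl)ccc2[nH]c1=O`, is the lower of the two numbers seen so far in an ADME assay on HepG2 2.2.15 cells (Homo sapiens) for cytotoxicity; a higher number here means that more compound is tolerated, a lower number that less compound is tolerated: compound 2 gives 120000 nM, while compound 1, `O=c1[nH]c2ccc(Cl)cc2c(-c2ccccc2Cl)c1CCO`, gives 380000 nM. For the measured compounds named here, the one measured step, a 3.2-fold lower number from compound 1 to compound 2 (0.50 log units; beyond the scatter), is the only guide available, and it concerns the same saturated chain carbon that is altered again here. Compound 3, `CCC(=O)OCCc1c(-c2ccccc2Cl)c2cc(Cl)ccc2[nH]c1=O`, carries (propanoyloxy)methyl in place of formyl on a saturated chain carbon bound to an aromatic carbon. In effect, compound 3 brings back the oxygen-bearing chain of compound 1 and extends it by a propanoyl group, so the measured step is read here mostly in reverse: the formyl whose arrival lowered the number is removed again. Going by the values given here, that reversal alone would argue for a number nearer that of compound 1, but the added propanoyl has no precedent among the measured compounds, so the expectation stays cautious and modest. Compound 3 is therefore expected to give 250000 nM in this assay, within a range of 100000 nM to 600000 nM. The corresponding expected step is a 2.1-fold higher number from compound 2 to compound 3 (0.32 log units; beyond the scatter), a modest rise rather than a large one.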

Compound 3, half-maximal cytotoxic concentration: 95000 nM
Estimate against measurement, compound 3: 2.6-fold (0.42 log units) above; measured number below the stated range.
By their numbers in this assay, from the lowest: compounds 3 and 2 (each within the scatter of the next); then compound 1.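

In this assay the swap of formyl for the larger (propanoyloxy)methyl group gives a 1.3-fold lower number from compound 2 to compound 3 (0.10 log units; within the scatter) and so the two compounds cannot be told apart, even though the entering group holds more heavy atoms than the one that leaves. The comparison with the free oxygen-bearing chain is clearer: propanoyl in place of hydrogen on that oxygen gives a 4.0-fold lower number from compound 1 to compound 3 (0.60 log units; beyond the scatter) and this points the same way as the earlier change to formyl, which gave a 3.2-fold lower number from compound 1 to compound 2 (0.50 log units; beyond the scatter) so among these three compounds, the one with the free chain end is tolerated at the highest concentration. Nothing measured here gives a reason for these numbers.

Going by these compounds, what remains open is how much the size of the ester matters, since a shorter acetyl or a longer butanoyl in place of propanoyl could either stay level with compound 3 or come closer to compound 1. On these data alone, it is equally open whether a carboxylic acid or an amine at the end of the chain would keep the number low or raise it again.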